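The source may hold more compounds than are shown below. What is called first, only, known or untested is meant among the compounds shown, and "the series" means these compounds.

In an ADME assay on BJ cells (Homo sapiens) for cytotoxicity, with a stated time of 72 h (on this read-out higher numbers stand for an effect only at larger amounts of compound and lower numbers for an effect already at smaller amounts), three compounds that share one core have been measured so far. Compound 1 `Cc1cc(NC(=O)Nc2ccc(C(C)(C)C)cc2)c2ccccc2n1` gives a real number, 20000 nM. Compound 2 `CSc1ccc(NC(=O)Nc2cc(C)nc3ccccc23)cc1` reads > 25000 nM, which is a limit of the assay and not a number. Compound 3 `Cc1cc(NC(=O)Nc2cccc([N+](=O)[O-])c2)c2ccccc2n1` reads > 25000 nM, and this too is a limit. Compound 3 therefore has no exact place on the scale, and the same holds for its neighbour at the limit of > 25000 nM in this assay, at which 2 of the 3 values shown sit.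

Compound 4 `Cc1cc(NC(=O)Nc2cccc(C(N)=O)c2)c2ccccc2n1` is compound 3 with one group exchanged: carbamoyl in place of nitro on an aromatic carbon. In words, this is carbamoyl in place of nitro on an aromatic carbon, meta to a large group.

Within the data shown here, only one measured step offers any guidance, and it concerns other groups: an at least 1.2-fold higher number from compound 1 to compound 2 (0.09 log units; that floor lies within the scatter). Among the measured compounds shown here, no measured compound carries carbamoyl, and no measured step starts from nitro. That single step stays within the scatter, so it gives no direction, and no step beyond the scatter is expected in this assay. The expected change is a step that the limit leaves unreadable from compound 3 to compound 4, and a second reading at the limit would be no surprise. For compound 4 the estimated value is 30000 nM, with an expected range from 15000 nM to 50000 nM.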

Compound 4, half-maximal effective concentration: > 25000 nM
Compound 4 gave a limit, no number; the forecaster's own chance of this, stated with the estimate: 85%; the middle value does not contradict the limit.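

Compound 4 reads > 25000 nM, which is a limit of the assay and not a number. Compound 3 also reads a limit, so no step can be read from compound 3 to compound 4. Whether carbamoyl and nitro differ at all in this assay stays open, and the compounds shown mostly share one mark: the limit of > 25000 nM in this assay, at which 3 of the 4 values shown sit.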